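A few compounds are considered here, and "the series" means these few. Any claim that something is new, unique, unknown or untested is made for them only; others in the source may bear on it.

Measured so far:
compound 1, `CCC(=O)N[C@@H]1CCCc2c1cncc2N1CCc2cc(Cl)ccc2C1=O`, 119 nM in an assay on cells for inhibition of cytochrome P450 11B2, mitochondrial (Homo sapiens), read by HTRF; on this read-out lower numbers stand for stronger inhibition and higher numbers for weaker inhibition
compound 2, `CC(=O)N[C@@H]1CCCc2c1cncc2N1C(=O)c2ccc(Cl)cc2[C@H]1C1CC1`, 100 nM in this assay

Compound 2 gives the lowest of the two numbers in this assay, and compound 1 sits within the scatter of it. Compound 3, `CC(=O)N[C@@H]1CCCc2c1cncc2N1Cc2cc(Cl)ccc2C1=O`, is not yet measured. It differs from compound 2 by hydrogen in place of cyclopropyl on a saturated ring carbon. Among the measured compounds shown here, no step between two measured compounds covers this kind of change, so the direction rests on no measured precedent. A small rise in number, on the edge of the scatter, is expected for the step of a 1.8-fold higher number from compound 2 to compound 3 (0.26 log units; within the scatter). Compound 3 is thus estimated at 180 nM, with a range of 60 nM to 550 nM.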

Compound 3, half-maximal inhibitory concentration: 44 nM
Estimate against measurement, compound 3: 4.1-fold (0.61 log units) above; measured number outside the range, below it.
By their numbers in this assay, from the lowest: compound 3; then compounds 2 and 1 (each within the scatter of the next).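

In this assay, among the compounds shown here, hydrogen in place of cyclopropyl on the saturated ring carbon next to the ring nitrogen gives a 2.3-fold lower number from compound 2 to compound 3 (0.36 log units; beyond the scatter) and is the only measured step at this position. The cyclopropyl is therefore not required on this carbon for inhibition, and the unsubstituted carbon gives the lower number. No supporting data bear on the reason for this step.

From the compounds shown here alone, whether methyl, hydroxyl or an amine on this carbon would keep the number of compound 3 or lose it remains open.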